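From Amino to Carboxy: Estimating Compound 4

The source may hold more compounds than are shown below. What is called first, only, known or untested is meant among the compounds shown, and "the series" means these compounds.

Measured in an assay on isolated protein for inhibition of Rho-associated protein kinase 2 (Homo sapiens), read by scintillation counting, radiometric assay and 33P incorporation, with a stated time of 40 min, in the presence of a further agent that is not named here; a lower number here means a stronger inhibitor, a higher number a weaker inhibitor:
compound 1 `O=C(COc1ccc2c(=O)ccoc2c1)Nc1cccc(NC(=O)c2ccccc2)c1` gives 16 nM
compound 2 `Cc1cc(C(=O)Nc2cccc(NC(=O)COc3ccc4c(=O)ccoc4c3)c2)no1` gives 5 nM
compound 3 `Nc1ccc(C(=O)Nc2cccc(NC(=O)COc3ccc4c(=O)ccoc4c3)c2)cc1` gives 83 nM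

Compound 3 has the highest number of the three and is the weakest inhibitor here; both of its steps to the others lie beyond the scatter: a 5.2-fold higher number from compound 1 to compound 3 (0.71 log units; beyond the scatter) and a 17-fold higher number from compound 2 to compound 3 (1.22 log units; beyond the scatter). Compound 4 `O=C(COc1ccc2c(=O)ccoc2c1)Nc1cccc(NC(=O)c2ccc(C(=O)O)cc2)c1` differs from compound 3 by carboxy in place of amino on an aromatic carbon. The step that bears most directly on this change is a 5.2-fold higher number from compound 1 to compound 3 (0.71 log units; beyond the scatter), in which placing an amino group on that aromatic carbon raised the number modestly. Going by the values given here, no measured step involves a carboxy group, and the direction of the new change is open. The expectation for compound 4 is a modest movement in this assay, a 1.4-fold lower number from compound 3 to compound 4 (0.14 log units; within the scatter). Compound 4 is estimated at 60 nM, with a range from 15 nM to 250 nM.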

Compound 4, half-maximal inhibitory concentration: 2030 nM
Compound 4: the middle estimate sits 34-fold (1.53 log units) below what was measured; measured number outside the range, above it.
By their numbers in this assay, from the lowest: compound 2; then compound 1; then compound 3; then compound 4.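

Carboxy at this place on the ring, para to a large group, proves far worse than amino (a 24-fold higher number from compound 3 to compound 4 (1.39 log units; beyond the scatter)), so the two groups are not interchangeable here. The loss is larger still against the unsubstituted phenyl (a 130-fold higher number from compound 1 to compound 4 (2.10 log units; beyond the scatter)) and against the 5-methyl-1,2-oxazol-3-yl group (a 410-fold higher number from compound 2 to compound 4 (2.61 log units; beyond the scatter)). Nothing available explains this loss. The compounds shown leave open whether a methyl ester or a primary amide in the same place would behave like carboxy or like amino.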